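Replacing the Dimethoxypropyl Urea Tail with a Basic Amine

The source may hold more compounds than are shown below. What is called first, only, known or untested is meant among the compounds shown, and "the series" means these compounds.

Of the compounds shown here, three sharing one core have been tested in a functional assay on A-431 cells (Homo sapiens) for antiproliferative activity, read by sulforhodamine B assay, with a stated time of 72 h; on this read-out higher numbers stand for weaker inhibition and lower numbers for stronger inhibition. Compound 1 `CS(=O)(=O)CCNC(=O)Nc1cc2c(Nc3ccc(F)c(Cl)c3)ncnc2cc1O[C@H]1CCOC1` gives 1570 nM. Compound 2 `CN(C)CCNC(=O)Nc1cc2c(Nc3ccc(F)c(Cl)c3)ncnc2cc1O[C@H]1CCOC1` gives 806 nM. Compound 3 `COC(CCNC(=O)Nc1cc2c(Nc3ccc(F)c(Cl)c3)ncnc2cc1O[C@H]1CCOC1)OC` gives 22000 nM, the highest of the three numbers, so it is the weakest inhibitor among them: the step from compound 1 is a 14-fold higher number from compound 1 to compound 3 (1.15 log units; beyond the scatter) and the step from compound 2 is a 27-fold higher number from compound 2 to compound 3 (1.44 log units; beyond the scatter).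

Compound 4 `CN(C)CCN(C)C(=O)Nc1cc2c(Nc3ccc(F)c(Cl)c3)ncnc2cc1O[C@H]1CCOC1` differs from compound 3 in one place: (2-(dimethylamino)ethyl)(methyl)amino in place of (3,3-dimethoxypropyl)amino on a carbonyl carbon. Going by the values given here, the most telling comparison is the one between compound 2 and compound 3, where the same kind of switch in the opposite direction gave a 27-fold higher number from compound 2 to compound 3 (1.44 log units; beyond the scatter). Among the compounds with values here, compound 4 carries a dimethylamino tail as compound 2 does, but additionally a methyl on the amino nitrogen, and no measured pair shows the effect of that methyl alone. The return to a dimethylamino tail points to a large drop in the number, while the added methyl makes the outcome less certain. Compound 4 is therefore expected to fall well below compound 3, with an estimated step of a 15-fold lower number from compound 3 to compound 4 (1.17 log units; beyond the scatter). The estimated value for compound 4 is 1500 nM, within a range from 400 nM to 6000 nM.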

Compound 4, half-maximal inhibitory concentration: 450 nM
Estimate against measurement, compound 4: 3.3-fold (0.52 log units) above; low and high end bracket the measured number.
By their numbers in this assay, from the lowest: compounds 4, 2 and 1 (each within the scatter of the next, the first and the last beyond it); then compound 3.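

In this assay, (2-(dimethylamino)ethyl)(methyl)amino in place of (3,3-dimethoxypropyl)amino on the carbonyl carbon gives a 49-fold lower number from compound 3 to compound 4 (1.69 log units; beyond the scatter), so a dimethylamino tail again stands far from the dimethoxy tail, now also with a methyl on the nitrogen. That methyl is the new piece of information: the step that isolates it is a 1.8-fold lower number from compound 2 to compound 4 (0.25 log units; within the scatter), which stays within the scatter, so among these compounds the amide hydrogen at this nitrogen can be replaced by methyl without a measurable loss of activity. The comparison with the methylsulfonyl tail also sharpens, since compound 2 lay within the scatter of compound 1, while the other dimethylamino compound gives a 3.5-fold lower number from compound 1 to compound 4 (0.54 log units; beyond the scatter), a modest step that changes both the tail and the nitrogen.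

Nothing measured here accounts for any of these steps. Still open, going by these compounds, is whether a longer chain before the dimethylamino group, a carboxylic acid at the end of the tail, or the same nitrogen methyl on the methylsulfonyl tail would keep the number in this range.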